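Cytotoxicity on Vero cells: from an aniline to an anisole

The compounds below may be only part of what the source reports. "The series", "measured", "known", "first", "only" and "open" are said of these compounds alone.

Measured compounds:
Compound 1 `CCOC(=O)c1cc(-c2cccc(OCc3cccc(Cl)c3)c2)on1` gives > 128000 nM in an ADME assay on Vero cells (Chlorocebus sabaeus) for cytotoxicity, with a stated time of 72 h; on this read-out higher numbers stand for weaker inhibition and lower numbers for stronger inhibition.
Compound 2 `CCOC(=O)c1cc(-c2cccc(OCc3cccc(C#N)c3)c2)on1` gives > 128000 nM in this assay.
Compound 3 `CCOC(=O)c1cc(-c2cccc(OCc3cccc(N)c3)c2)on1` gives > 128000 nM in this assay.

Each of these three values is a limit of this assay rather than a measured number, as the limit of > 128000 nM in this assay, at which 3 of the 3 values shown sit, states. Compound 3 therefore stands at the same limit as the other two, and no ordering among them can be read.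

Compound 4 `CCOC(=O)c1cc(-c2cccc(OCc3cccc(OC)c3)c2)on1` has not yet been measured. It differs from compound 3 by methoxy in place of amino on an aromatic carbon.

The measured steps that touch the same position are a step that the two limits leave unreadable from compound 1 to compound 3 and a step that the two limits leave unreadable from compound 2 to compound 3, and also a step that the two limits leave unreadable from compound 1 to compound 2; none of them has a readable size, since every compound involved sits at the limit. The swap of chloro, cyano and amino at this position thus never brought any compound into the measurable range of this assay.

Given that, the step that the limit leaves unreadable from compound 3 to compound 4 is expected to be none beyond the scatter, with compound 4 most likely again reported as a limit. The estimate for compound 4 in this assay is 150000 nM, in a range from 60000 nM to 400000 nM.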

Compound 4, half-maximal inhibitory concentration: > 128000 nM
Compound 4: a limit, no number; the forecaster's own chance of this, stated with the estimate: 85%; the middle value is on the limit's open side.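

For the compounds shown here, no step from compound 1, compound 2 or compound 3 to compound 4 can be read in this assay, since all four compounds give a limit rather than a number: the limit of > 128000 nM in this assay, at which 4 of the 4 values shown sit.

Left open is whether these four compounds differ at all in this assay, and at what concentration, if any, each would reach half-maximal inhibition.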